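This account rests on a few compounds, and the source may have more. Where it says the series, first, only, none or still open, it means among the compounds named here.

Measured in a functional assay on CHO cells for agonist activity at prostaglandin E2 receptor EP3 subtype (Homo sapiens), read by fluorescence and calcium flux; a higher number here means that more compound is needed for the effect, a lower number that less compound is needed:
compound 1 `O=C(O)c1csc([C@H]2CC[C@@H]3[C@@H](/C=C/COc4ccccc4)[C@H](O)C[C@@H]3O2)n1`: 7600 nM
compound 2 `O=C(O)c1csc([C@H]2CC[C@@H]3[C@@H](/C=C/CCCOc4ccccc4)[C@H](O)C[C@@H]3O2)n1`: 360 nM

Among the compounds with values here, compound 2 gives the lowest number of the two; the only measured step, a 21-fold lower number from compound 1 to compound 2 (1.32 log units; beyond the scatter), came from lengthening the chain. Compound 3 `O=C(O)c1csc([C@H]2CC[C@@H]3[C@@H](/C=C/[C@@H](O)COc4ccccc4)[C@H](O)C[C@@H]3O2)n1` keeps the chain length of compound 2 and differs by 1-hydroxy-2-phenoxyethyl in place of 3-phenoxypropyl on a double-bonded chain carbon bound to a double-bonded chain carbon. Within the data shown here, no measured step bears on adding a hydroxyl with a defined stereocentre, so the step is expected to be small, if anything a somewhat higher number, a 1.9-fold higher number from compound 2 to compound 3 (0.29 log units; within the scatter). For compound 3 the estimate in this assay is 700 nM, range 150 nM to 3500 nM.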

Compound 3, half-maximal effective concentration: 0.8 nM
Compound 3: middle estimate off by 880-fold (2.94 log units), on the high side, outside the stated range (below it).
By their numbers in this assay, from the lowest: compound 3; then compound 2; then compound 1.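

With 10 heavy atoms in both groups, 1-hydroxy-2-phenoxyethyl in place of 3-phenoxypropyl gives a 450-fold lower number from compound 2 to compound 3 (2.65 log units; beyond the scatter) in this assay and so shows that this position responds to more than chain length. Measured against phenoxymethyl, the same group gives a 9500-fold lower number from compound 1 to compound 3 (3.98 log units; beyond the scatter) and far exceeds a 21-fold lower number from compound 1 to compound 2 (1.32 log units; beyond the scatter) from lengthening alone. Nothing at hand accounts for the gain.

Going by these compounds, whether the gain depends on the hydroxyl itself or on its defined stereocentre stays open. The opposite stereocentre, or a methoxy group or an amine in place of the hydroxyl, would separate these two readings.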